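The source may hold more compounds than are shown below. What is called first, only, known or untested is meant among the compounds shown, and "the series" means these compounds.

Measured in a toxicity assay on MT4 cells (Homo sapiens) for cytotoxicity, read by MTT assay, with a stated time of 5 days; a higher number here means that more compound is tolerated, a lower number that less compound is tolerated:
Compound 1 `Cc1cnc(Nc2ccc(C#N)cc2)nc1Nc1c(F)cc(-c2cncc(C#N)c2)cc1F`: 50000 nM
Compound 2 `Cc1cc(-c2ccnc3ccccc23)cc(C)c1Nc1ccnc(Nc2ccc(C#N)cc2)n1`: 3500 nM

Compound 2, at 3500 nM, has the lower of the two numbers, and compound 1, at 50000 nM, stands apart from it beyond the usual scatter. Compound 3 `Cc1cc(-c2ccnc(C(F)(F)F)c2)cc(C)c1Nc1ccnc(Nc2ccc(C#N)cc2)n1` has not yet been measured in this assay. It carries 2-(trifluoromethyl)pyridin-4-yl in place of quinolin-4-yl on an aromatic carbon, meta to two methyl groups (2-(trifluoromethyl)pyridin-4-yl in place of quinolin-4-yl on an aromatic carbon). Among the measured compounds shown here, no measured pair differing in one place exists to gauge such a change, so the expectation is loose. Compound 2 holds the lower number, which leaves more room upward, and a modest rise is expected. The estimated change is a 2.3-fold higher number from compound 2 to compound 3 (0.36 log units; beyond the scatter), just beyond the scatter. The expected value for compound 3 is 8000 nM, within an estimated range of 2500 nM to 30000 nM.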

Compound 3, half-maximal cytotoxic concentration: 6100 nM
Compound 3: the middle estimate sits 1.3-fold (0.12 log units) above what was measured; the range from low to high includes it.
By their numbers in this assay, from the lowest: compounds 2 and 3 (each within the scatter of the next); then compound 1.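

In this assay, the first exchange readable at this place, on an aromatic carbon meta to two methyl groups, puts 2-(trifluoromethyl)pyridin-4-yl in place of quinolin-4-yl and gives a 1.7-fold higher number from compound 2 to compound 3 (0.24 log units; within the scatter), so the read-out does not separate the two compounds. The exchange gives up the six-membered aromatic ring of carbon only and brings in three fluorine atoms at an equal count of 10 heavy atoms, and this place tolerates that change in structure without a step beyond the scatter. No measured property of either group bears on this result.

The compounds shown leave open whether an amine, a carboxylic acid or a morpholine at this place would also stay within the scatter of compound 2. They also leave open whether plain pyridin-4-yl, without the trifluoromethyl group, would do the same.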